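Methyl in Place of Hydrogen: Compound 2 to Compound 3

A few compounds are considered here, and "the series" means these few. Any claim that something is new, unique, unknown or untested is made for them only; others in the source may bear on it.

Measured compounds:
compound 1 `Cn1cc(/C=C/C(=O)c2ccccc2F)cc1/C=C/C(=O)NO`, 3400 nM
compound 2 `C/C(=C\c1cc(/C=C/C(=O)NO)n(C)c1)C(=O)c1ccccc1`, 570 nM

Within the data shown here, in an assay on isolated protein for inhibition of histone deacetylase HD1B (Zea mays) (on this read-out higher numbers stand for weaker inhibition and lower numbers for stronger inhibition), compound 2 gives 570 nM, the lowest of the two numbers known here. Its nearest neighbour, compound 1, gives 3400 nM in this assay, a gap that lies beyond the scatter. Among the measured compounds shown here, no single-point step connects compound 1 and compound 2, so their two values stand as they are.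

Compound 3 `CC/C(=C\c1cc(/C=C/C(=O)NO)n(C)c1)C(=O)c1ccccc1` has not yet been measured. It differs from compound 2 by methyl in place of hydrogen on a saturated chain carbon bound to a double-bonded chain carbon; cut one bond further out, the change reads methyl to ethyl. For the measured compounds named here, no measured pair shows such a step, so nothing here sets its size.

For compound 3 in this assay the expected step is a 1.2-fold higher number from compound 2 to compound 3 (0.09 log units; within the scatter), that is, no change beyond the scatter. Compound 3 is estimated at 700 nM, with a range from 250 nM to 2000 nM.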

Compound 3, half-maximal inhibitory concentration: 4500 nM
For compound 3 the middle estimate is 6.4-fold (0.81 log units) below the measured one; the measured number lies above the stated range.
By their numbers in this assay, from the lowest: compound 2; then compounds 1 and 3 (each within the scatter of the next).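

Methyl in place of hydrogen on a saturated chain carbon bound to a double-bonded chain carbon brings a 7.9-fold higher number from compound 2 to compound 3 (0.90 log units; beyond the scatter) in this assay, which means weaker inhibition. Among these compounds, the earlier compounds offered no single-point step, so this is the first change here confined to one place, and it shows that the read-out is sensitive at this position to the gain of a single carbon, with methyl becoming ethyl. Nothing available here explains why this small change has an effect of this size.

The compounds shown leave open whether a longer chain such as propyl at this place would weaken inhibition further or give it back. They also leave open how a group of other atoms there, such as hydroxymethyl or an amine, would read in this assay.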